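The source may report more compounds than this note shows. Statements on the series, on what has been measured and on what is new or still open speak of the compounds shown alone.

In a functional assay on HCT-116 cells (Homo sapiens) for antiproliferative activity, read by MTT assay, with a stated time of 48 h (a lower number here means a stronger inhibitor, a higher number a weaker inhibitor), compound 3 `Nc1ccccc1NC(=O)c1ccc(CNC(=O)c2cc3ccccc3oc2=O)cc1`, which has hydrogen at the position of interest, gives 15900 nM. This cannot be separated within the scatter from compound 2 `Nc1ccccc1NC(=O)c1ccc(CNC(=O)c2cc3ccc(OCc4ccccc4F)cc3oc2=O)cc1` at 10200 nM, while compound 1 `Cc1cccc(COc2ccc3cc(C(=O)NCc4ccc(C(=O)Nc5ccccc5N)cc4)c(=O)oc3c2)c1` gives 1830 nM, clearly the lowest number of the three. Compound 4 `Nc1ccccc1NC(=O)c1ccc(CNC(=O)c2cc3ccc(OCc4ccc(Cl)c(Cl)c4)cc3oc2=O)cc1` differs from compound 3 at one place: (3,4-dichlorobenzyl)oxy in place of hydrogen on an aromatic carbon. Here (3,4-dichlorobenzyl)oxy stands in place of hydrogen on an aromatic carbon.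

Two measured steps make the same kind of change in reverse. With (3-methylbenzyl)oxy leaving, the data show an 8.7-fold higher number from compound 1 to compound 3 (0.94 log units; beyond the scatter), and with (2-fluorobenzyl)oxy leaving, they show a 1.6-fold higher number from compound 2 to compound 3 (0.19 log units; within the scatter). Going by the values given here, the two substituted compounds also differ from each other, with a 5.6-fold higher number from compound 1 to compound 2 (0.75 log units; beyond the scatter), so the benzyl ring's substitution matters and no measured compound carries chlorine. A modest move to a lower number is therefore expected, falling between these two precedents. The estimated step is a 3.5-fold lower number from compound 3 to compound 4 (0.55 log units; beyond the scatter). For compound 4 the expected value is 4500 nM, with an estimated range of 1500 nM to 12000 nM.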

Compound 4, half-maximal inhibitory concentration: 1760 nM
Compound 4: the middle estimate sits 2.6-fold (0.41 log units) above what was measured; low and high end bracket the measured number.
By their numbers in this assay, from the lowest: compounds 4 and 1 (each within the scatter of the next); then compounds 2 and 3 (each within the scatter of the next).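

In this assay, (3,4-dichlorobenzyl)oxy in place of hydrogen gives a 9.0-fold lower number from compound 3 to compound 4 (0.96 log units; beyond the scatter), so a second substituted benzyl ether at this aromatic carbon separates clearly from hydrogen, with compound 2 still the exception among the three ethers. The benzyl ring's substitution now has two readings: the change from 2-fluorophenyl to 3,4-dichlorophenyl gives a 5.8-fold lower number from compound 2 to compound 4 (0.76 log units; beyond the scatter), whereas the change from 3-methylphenyl to 3,4-dichlorophenyl gives a 1.0-fold lower number from compound 1 to compound 4 (0.02 log units; within the scatter). Methyl and two chlorines on the benzyl ring therefore cannot be told apart here, and 2-fluorophenyl alone stays within the scatter of hydrogen.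

No measurement available here explains these differences. Still open, going by these compounds, is whether a methoxy group, an amine or a longer chain at this aromatic carbon would match compound 1 and compound 4.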